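Working notes: ethynyl for methoxy in the urea series

This account rests on a few compounds, and the source may have more. Where it says the series, first, only, none or still open, it means among the compounds named here.

Compound 1 `O=C(Nc1ccc(-c2noc(-c3cccc(NS(=O)(=O)c4ccccc4)c3)n2)c(Cl)c1)c1cccnc1` gives in a functional assay on MDA-MB-231 cells (Homo sapiens) for antiproliferative activity, read by MTT assay, with a stated time of 72 h (on this read-out lower numbers stand for stronger inhibition and higher numbers for weaker inhibition), only a limit, > 10000 nM.
Compound 2 `O=C(Nc1ccc(Cl)cc1)Nc1cccc(-c2nc(-c3ccc(NC(=O)c4cccnc4)cc3Cl)no2)c1` gives in this assay likewise only a limit, > 10000 nM.
Compound 3 `COc1ccc(NC(=O)Nc2cccc(-c3nc(-c4ccc(NC(=O)c5cccnc5)cc4Cl)no3)c2)cc1` gives in this assay a number, 3000 nM.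

For the measured compounds named here, compound 3 holds the only number in the set; the other two entries are limits, as recorded in the limit of > 10000 nM in this assay, at which 2 of the 3 values shown sit. The step of an at least 3.3-fold lower number from compound 1 to compound 3 (0.52 log units; beyond the scatter) and the step of an at least 3.3-fold lower number from compound 2 to compound 3 (0.52 log units; beyond the scatter) both run toward compound 3, each readable only as a lower bound on the change. The step that the two limits leave unreadable from compound 1 to compound 2 cannot be read at all.

The next compound, compound 4 `C#Cc1ccc(NC(=O)Nc2cccc(-c3nc(-c4ccc(NC(=O)c5cccnc5)cc4Cl)no3)c2)cc1`, differs from compound 3 in one place: ethynyl in place of methoxy on an aromatic carbon. Going by the values given here, no measured step swaps a group at this position for a hydrocarbon chain. The closest comparison is the step of an at least 3.3-fold lower number from compound 2 to compound 3 (0.52 log units; beyond the scatter), where exchanging one group on the same aromatic carbon for another moved the value out of the limit region. That step shows the substituent at this position counts, but gives no direction for the methoxy-to-ethynyl exchange. The expectation for this assay is therefore a modest shift, with a somewhat weaker outcome judged more likely than a stronger one, and a real chance that only a limit is returned.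

Compound 4 is expected near 5000 nM, within 1500 nM to 20000 nM.
For compound 4 this estimate implies a step of a 1.7-fold higher number from compound 3 to compound 4 (0.22 log units; within the scatter).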

Compound 4, half-maximal inhibitory concentration: > 10000 nM
Compound 4: no number, only a limit; the forecaster's own chance of this, stated with the estimate: 35%; middle value at least 2.0-fold (0.30 log units) away from the limit.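

In this assay, ethynyl in place of methoxy on the aromatic carbon para to a large group gives an at least 3.3-fold higher number from compound 3 to compound 4 (0.52 log units; beyond the scatter). With an at least 3.3-fold lower number from compound 2 to compound 3 (0.52 log units; beyond the scatter), the position now has two replacements for methoxy, chloro and ethynyl, and both leave the urea series with only a limit, so among the three groups shown here only methoxy returns a number. The steps that join one limit to another, those linking compound 4 with compound 1 and with compound 2, cannot be read, and the series still rests on a single number: the limit of > 10000 nM in this assay, at which 3 of the 4 values shown sit.

Compound 2 and compound 4 both stand as limits, so chloro and ethynyl cannot be ordered against each other at this position. Also open, going by these compounds, is whether an amine, a hydroxyl or an ethoxy group on the same carbon would match or improve on compound 3 at 3000 nM, and so whether methoxy itself matters or other groups would serve as well.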